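A few compounds are considered here, and "the series" means these few. Any claim that something is new, unique, unknown or untested is made for them only; others in the source may bear on it.

Measured compounds: compound 1 `Cc1csc(NC(=O)c2cccc(Cl)c2)n1` gives 5490 nM in an assay on membranes from brain for binding affinity to metabotropic glutamate receptor 5 (Rattus norvegicus); on this read-out lower numbers stand for stronger inhibition and higher numbers for weaker inhibition; compound 2 `Cc1cccc(NC(=O)c2ccccc2)n1` gives 35000 nM; compound 3 `O=C(Nc1ccccn1)c1ccccc1` gives 95400 nM.

Compound 2 stands second highest of the three numbers, nearest to compound 3 and furthest from compound 1. Compound 4 `Cc1cccc(C(=O)Nc2cccc(C)n2)c1` is not yet measured; it differs from compound 2 by methyl in place of hydrogen on an aromatic carbon, placed on an aromatic carbon of a six-membered aromatic ring of carbon only, meta to a large group. Within the data shown here, the only measured step that bears on it is a 2.7-fold higher number from compound 2 to compound 3 (0.44 log units; beyond the scatter), which concerns a methyl on the other ring of the shared core, not the one changed here, so it is only an indirect guide. Among the measured compounds shown here, no measured pair shows a methyl added at this place. A methyl on the core ring mattered modestly in the step from compound 2 to compound 3, so a second methyl is expected to shift the number by a small step, most likely downward, as a 1.8-fold lower number from compound 2 to compound 4 (0.24 log units; within the scatter). Compound 4 is therefore estimated at 20000 nM, within 7000 nM to 60000 nM.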

Compound 4, half-maximal inhibitory concentration: 1840 nM
Beside the measured number, compound 4's estimate is 11-fold (1.04 log units) above it; the whole stated range lies above it.
By their numbers in this assay, from the lowest: compound 4; then compound 1; then compound 2; then compound 3.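

In this assay a single methyl in place of hydrogen, on an aromatic carbon of a six-membered aromatic ring of carbon only and meta to a large group, brings a 19-fold lower number from compound 2 to compound 4 (1.28 log units; beyond the scatter), so this place on the shared core responds strongly to one added carbon. The earlier compounds shown here showed only a change of methyl on the other ring, a 2.7-fold higher number from compound 2 to compound 3 (0.44 log units; beyond the scatter), and that modest step gave no sign that a methyl here could matter so much. Nothing available explains the size of the new step.

The compounds shown leave open whether this gain is particular to methyl, since a chlorine atom, a methoxy group or an ethyl chain at the same place could give a smaller or a larger step. They also leave open how methyl behaves elsewhere on this ring.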